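Replacing methylcarbamoyl by thiazolyl on the shared core

A few compounds are considered here, and "the series" means these few. Any claim that something is new, unique, unknown or untested is made for them only; others in the source may bear on it.

compound 1 `c1ccc2c(c1)CCC2c1ncc[nH]1`: > 10000 nM
compound 2 `CNC(=O)c1cccc2c1CCC2c1ncc[nH]1`: > 10000 nM

In a functional assay on CHO cells for agonist activity at Alpha-1B adrenergic receptor (Homo sapiens), read by FLIPR and calcium flux (on this read-out lower numbers stand for an effect already at smaller amounts and higher numbers for an effect only at larger amounts of compound), compound 1 gives > 10000 nM, a limit of the assay. Compound 2 gives > 10000 nM in this assay, also a limit. The step that the two limits leave unreadable from compound 1 to compound 2 is therefore not sizeable; both values sit at the limit of > 10000 nM in this assay, at which 2 of the 2 values shown sit. Compound 3 `c1cc(-c2nccs2)c2c(c1)C(c1ncc[nH]1)CC2` differs from compound 2 by 1,3-thiazol-2-yl in place of methylcarbamoyl on an aromatic carbon. Among the measured compounds shown here, no measured step has a readable size, so for this assay no step beyond the scatter can be expected in either direction. Compound 3 is expected at 15000 nM (range 3000 nM to 100000 nM), most likely again as a limit. The expected step is a step that the limit leaves unreadable from compound 2 to compound 3.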

Compound 3, half-maximal effective concentration: > 10000 nM
Compound 3 ended at the assay's limit (the forecaster's own chance of this, stated with the estimate: 80%); the middle value does not contradict the limit.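

In this assay no step can be read among compound 1, compound 2 and compound 3, each of which gives only a limit of the assay: the limit of > 10000 nM in this assay, at which 3 of the 3 values shown sit.

The compounds shown leave open whether hydrogen, methylcarbamoyl or 1,3-thiazol-2-yl on this aromatic carbon makes any difference to the read-out.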